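Swapping the Benzothiazole for a Methyltriazole on the Sulfur

A few compounds are considered here, and "the series" means these few. Any claim that something is new, unique, unknown or untested is made for them only; others in the source may bear on it.

Measured so far:
compound 1 `Cn1c(-c2ccc(NC(=O)CCl)cc2)nc(-c2ccccc2)c1-c1ccccc1`: 42.8%
compound 2 `Cn1c(-c2ccc(NC(=O)CSc3nc4ccccc4s3)cc2)nc(-c2ccccc2)c1-c1ccccc1`: 59%

Two compounds share a core and differ only in the group carried on the amide side chain. In a functional assay on MCF7 cells (Homo sapiens) for cytotoxicity, read by MTT assay, with a stated time of 24 h, tested at 32 ug/mL (a higher number here means a stronger effect of the compound at the concentration tested, a lower number a weaker effect), compound 1 gives 42.8%. In the same assay compound 2 gives 59%. Among the measured compounds shown here, compound 2 thus stands highest of the two numbers, set apart by the one measured step, a number 16.2 percentage points higher from compound 1 to compound 2 (beyond the scatter), a modest change beyond the scatter.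

Compound 3 `Cn1cnnc1SCC(=O)Nc1ccc(-c2nc(-c3ccccc3)c(-c3ccccc3)n2C)cc1` is not yet measured. It differs from compound 2 by 4-methyl-4H-1,2,4-triazol-3-yl in place of 1,3-benzothiazol-2-yl on a sulfur. For the measured compounds named here, the single measured step concerned another exchange, chloro for (1,3-benzothiazol-2-yl)sulfanyl, so no measured step bears directly on the present one. Because a number 16.2 percentage points higher from compound 1 to compound 2 (beyond the scatter) was only modest, a step of small to modest size is expected in this assay. The 1,3-benzothiazol-2-yl introduced by that step now leaves. The expected step is more likely downward than upward, with a result within the scatter also possible. Compound 3 is therefore estimated at 48%, in a range from 30% to 66%, which corresponds to an expected step of a number 11 percentage points lower from compound 2 to compound 3 (beyond the scatter).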

Compound 3, a percentage reported as activity, at one concentration (the size of the read-out at that concentration, not a potency): 89.2%
The estimate for compound 3 lay 41.2 percentage points below the measured number, and the stated range ends below it.
By their numbers in this assay, from the lowest: compound 1; then compound 2; then compound 3.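

In this assay, 4-methyl-4H-1,2,4-triazol-3-yl in place of 1,3-benzothiazol-2-yl on the sulfur gives a number 30.2 percentage points higher from compound 2 to compound 3 (beyond the scatter) and so shows that the group carried on the sulfur, not just the replacement of chloro, governs the read-out at this position. Measured against the chloro compound, the (4-methyl-4H-1,2,4-triazol-3-yl)sulfanyl group gives a number 46.4 percentage points higher from compound 1 to compound 3 (beyond the scatter) as a large step, whereas the (1,3-benzothiazol-2-yl)sulfanyl group gave only a number 16.2 percentage points higher from compound 1 to compound 2 (beyond the scatter) as a modest one. The entering group has a single five-membered aromatic ring and lacks the six-membered aromatic ring of carbon only, so in this pair that second ring is not needed for a high number.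

Among the compounds shown here, nothing available here explains why this exchange raises the number so far. Going by these compounds, it also remains open whether the methyl on the triazole contributes to the result, and how a morpholine on the saturated chain carbon, or a longer chain between the sulfur and the carbonyl, would read in this assay at the same concentration.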